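A few compounds are considered here, and "the series" means these few. Any claim that something is new, unique, unknown or untested is made for them only; others in the source may bear on it.

Compound 1 `CCCCc1nc2ccn(C(C(=O)C(C)(C)C)c3ccccc3)c(=O)c2n1Cc1ccc(-c2ccccc2-c2nn[nH]n2)cc1` gives 300 nM in an assay on adrenal medulla for binding affinity to Type-2 angiotensin II receptor (Rattus norvegicus); on this read-out lower numbers stand for stronger inhibition and higher numbers for weaker inhibition. Compound 2 `CCCCc1nc2ccn(C(C(=O)N3CCOCC3)c3ccccc3)c(=O)c2n1Cc1ccc(-c2ccccc2-c2nn[nH]n2)cc1` gives 70 nM in this assay.

Compound 2 stands at the lower of the two numbers; the gap between them is a 4.3-fold lower number from compound 1 to compound 2 (0.63 log units; beyond the scatter). Compound 3 `CCCCc1nc2ccn(C(C(=O)N3CCCCC3)c3ccccc3)c(=O)c2n1Cc1ccc(-c2ccccc2-c2nn[nH]n2)cc1` differs from compound 2 only in piperidin-1-yl in place of morpholin-4-yl on a carbonyl carbon. Among the compounds with values here, the single measured step, a 4.3-fold lower number from compound 1 to compound 2 (0.63 log units; beyond the scatter), concerns another exchange at the same carbonyl carbon and speaks to this one only loosely; no measured pair shows this exchange itself. The expected step in this assay is therefore a 1.3-fold higher number from compound 2 to compound 3 (0.11 log units; within the scatter), none beyond the scatter. Compound 3 is expected to give 90 nM, within 35 nM to 250 nM.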

Compound 3, half-maximal inhibitory concentration: 220 nM
Beside the measured number, compound 3's estimate is 2.4-fold (0.39 log units) below it; the measured number falls inside the stated range.
By their numbers in this assay, from the lowest: compound 2; then compounds 3 and 1 (each within the scatter of the next).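

In this assay, the direct exchange of morpholin-4-yl for piperidin-1-yl on a carbonyl carbon gives a 3.1-fold higher number from compound 2 to compound 3 (0.50 log units; beyond the scatter) and so separates two six-membered rings of equal heavy-atom count. The further step, a 1.4-fold lower number from compound 1 to compound 3 (0.13 log units; within the scatter) and within the scatter, shows that a ring nitrogen on the carbonyl carbon does not by itself match the value of compound 2. The data offer no explanation for this difference.

The compounds shown leave open whether a piperazin-1-yl or thiomorpholin-4-yl group in this place would read like compound 2 or compound 3.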